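Working notes: Z to E change at compound 3

The source may hold more compounds than are shown below. What is called first, only, known or untested is meant among the compounds shown, and "the series" means these compounds.

Compound 1 `CC/C(=C(\c1ccc(NC(=O)C(C)C)cc1)c1ccc(OC)cc1)c1ccc(O)cc1` gives 3700 nM
Compound 2 `CC/C(=C(/c1ccccc1)c1ccc(NC(=O)C(C)C)cc1)c1ccc(Cl)cc1Cl` gives 8200 nM
Compound 3 `CC/C(=C(\c1ccccc1)c1ccc(NC(=O)C(C)C)cc1)c1ccc(O)cc1` gives 3800 nM

All three numbers come from a functional assay on HeLa cells (Homo sapiens) for inhibition, read by trypan blue exclusion, with a stated time of 72 h (on this read-out higher numbers stand for weaker inhibition of growth and lower numbers for stronger inhibition of growth), and form a small set. Compound 3 (3800 nM) lies within the scatter of compound 1 (3700 nM). Its number is lower, beyond the scatter, than that of compound 2 (8200 nM). Within the data shown here, no two measured compounds differ in one place only, so the series offers no measured step for scaling the next change.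

The next compound is compound 4 `CC/C(=C(/c1ccccc1)c1ccc(NC(=O)C(C)C)cc1)c1ccc(O)cc1` and the change is the two compounds have the same atoms and bonds and differ only in configuration as drawn: 1 of 1 stereo elements differ; a double bond is drawn Z in compound 3 and E in compound 4 (nothing leaves and nothing enters, and a double bond is drawn Z in compound 3 and E in compound 4). Among the measured compounds shown here, no measured pair isolates such a change, so the data fix neither its size nor its direction. In this assay the working expectation is no step beyond the scatter, with no favoured direction, and the estimated move is a 1.1-fold higher number from compound 3 to compound 4 (0.02 log units; within the scatter) for now. The estimate starts from compound 3 (3800 nM), and its range is kept wide enough to take in the number of compound 2 (8200 nM). For compound 4 the estimated value is 4000 nM (expected range 1800 nM to 9000 nM).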

Compound 4, concentration for 50% growth inhibition: 5100 nM
For compound 4 the middle estimate is 1.3-fold (0.11 log units) below the measured one; the measured number falls inside the stated range.
By their numbers in this assay, from the lowest: compounds 1, 3, 4 and 2 (each within the scatter of the next, the first and the last beyond it).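

In this assay, among these compounds, the change of double bond configuration alone gives a 1.3-fold higher number from compound 3 to compound 4 (0.13 log units; within the scatter), the first measured step of its kind, and it does not separate the two isomers. Compound 4 also gives the series two single-place steps on substituents: 4-hydroxyphenyl in place of 2,4-dichlorophenyl gives a 1.6-fold lower number from compound 2 to compound 4 (0.21 log units; within the scatter), and hydrogen in place of methoxy on an aromatic carbon gives a 1.4-fold higher number from compound 1 to compound 4 (0.14 log units; within the scatter), so none of the three changes moves the number beyond the scatter in this assay. The first step can be read as configuration alone, with no substituent change alongside it: the fact that compounds 3 and 4 differ only in the configuration as drawn.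

Going by these compounds, whether the Z to E change stays this small with the methoxy of compound 1 in place remains open, since that step rests on a single pair. Also open is whether an amine or a carboxylic acid in place of the hydroxy of the 4-hydroxyphenyl group would give a step beyond the scatter in this assay, as all the substituent steps shown here lie within it.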